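The source may report more compounds than this note shows. Statements on the series, on what has been measured and on what is new or still open speak of the compounds shown alone.

Working notes on the aziridinyl quinone series. The measure throughout is a functional assay on L1210 cells (Mus musculus), with a stated time of 1 days; a lower number here means a less potent compound, a higher number a more potent compound, by a factor of ten per unit of this negative logarithm. Of the compounds shown here, two have numbers so far. Compound 1 `O=C1C(CCO)=C(N2CC2)C(=O)C(CCO)=C1N1CC1` carries two 2-hydroxyethyl chains on the shared core and in this assay gives 5.93. Compound 2 `CC1=C(N2CC2)C(=O)C(CCCOC(N)=O)=C(N2CC2)C1=O` carries a methyl group and a carbamate-bearing chain and in this assay gives 5.55. Compound 2 stands lowest of the two, with compound 1 the nearer neighbour, beyond the scatter above it.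

The next compound, compound 3 `COC(CO)C1=C(N2CC2)C(=O)C(C)=C(N2CC2)C1=O`, arises from compound 2 by one change: a group of 5 heavy atoms (3 carbon, 2 oxygen; no ring) in place of a group of 7 heavy atoms (4 carbon, 1 nitrogen, 2 oxygen; no ring), on a double-bonded ring carbon. Within the data shown here, no step between two measured compounds matches this change, so the expectation rests on the two values alone. The step of a number 0.15 log units higher from compound 2 to compound 3 (within the scatter) is expected to be small and upward, not beyond the scatter. Compound 3 is accordingly estimated at 5.7, with a range from 5.2 to 6.2.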

Compound 3, logarithm of the reciprocal of the active concentration, log(1/C): 6.05
Estimate against measurement, compound 3: 0.35 log units below, within the range that was stated.
By their numbers in this assay, from the lowest: compound 2; then compounds 1 and 3 (each within the scatter of the next).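

In this assay putting 2-hydroxy-1-methoxyethyl in place of the carbamate-bearing chain gives a number 0.50 log units higher from compound 2 to compound 3 (beyond the scatter) and so shows that this double-bonded ring carbon, next to the ring atom that bears an aziridin-1-yl group, responds to the group it carries. The leaving and entering groups have the same counts of hydrogen-bond donors and acceptors, so those counts alone do not account for the difference between this pair. No measurement at hand speaks to the reason for this step.

The compounds shown do not separate the contribution of the methoxy group from that of the hydroxyl group within the 2-hydroxy-1-methoxyethyl group. From the compounds shown here alone, how this position would respond to an amine, a carboxylic acid or a longer chain, with the methyl group held in place, remains open.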